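The source may report more compounds than this note shows. Statements on the series, on what has been measured and on what is new or still open speak of the compounds shown alone.

Compound 1 `ClCc1ccc(Cn2cnc3c(Cl)ncnc32)cc1`: in a functional assay on OVCAR-3 cells (Homo sapiens) for cytotoxicity, read by sulforhodamine B assay, with a stated time of 48 h (a higher number here means a weaker inhibitor of growth, a lower number a stronger inhibitor of growth), compound 1 gives 1380 nM.
Compound 2 `ClCc1ccccc1Cn1cnc2c(Cl)nc(Cl)nc21`: in this assay compound 2 gives 210 nM.

Compound 2 has the lowest number of the two measured; the nearest, compound 1, stands higher by a gap that lies beyond the usual scatter. Compound 3 `ClCc1ccccc1Cn1cnc2c(Cl)ncnc21` follows from compound 2 by a single change: hydrogen in place of chloro on an aromatic carbon. Among the measured compounds shown here, no pair of measured compounds traces this change, so its size cannot be read from what has been measured; the two values in hand only show that compound 2 sits well below compound 1. The step of a 2.4-fold higher number from compound 2 to compound 3 (0.38 log units; beyond the scatter) is the expected outcome, a modest move toward a higher number. Compound 3 is therefore expected to give 500 nM in this assay, with an estimated range from 150 nM to 1700 nM.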

Compound 3, concentration for 50% growth inhibition: 1410 nM
The estimate for compound 3 lay 2.8-fold (0.45 log units) below the measured number; the range from low to high includes it.
By their numbers in this assay, from the lowest: compound 2; then compounds 1 and 3 (each within the scatter of the next).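

Putting hydrogen in place of chloro on the aromatic carbon between two ring nitrogen atoms gives a 6.7-fold higher number from compound 2 to compound 3 (0.83 log units; beyond the scatter) in this assay, so this position is not indifferent to the change. Among the compounds shown here, this is the first measured pair that isolates the chloro group here, and within this pair the lower number goes with the compound that carries it. Nothing at hand accounts for the size of the step.

The compounds shown hold only chloro and hydrogen at this position, so it stays open where an amine, a methoxy group or a fluoro group there would fall. They also leave open whether the same change gives a step of similar size with the chloromethyl group placed as in compound 1.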